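Thiazolyl sulfone in place of fluorophenyl sulfone in the series

The source may report more compounds than this note shows. Statements on the series, on what has been measured and on what is new or still open speak of the compounds shown alone.

Compound 1 `CC(O)(C(=O)Nc1ccc(S(=O)(=O)c2cccc(F)c2)cc1)C(F)(F)F` and compound 2 `CC(O)(C(=O)Nc1ccc(C(=O)c2ccccc2)c(F)c1)C(F)(F)F` share the same core. In a functional assay (Cavia porcellus) with sulfonylurea receptors; K-ATP channels (Homo sapiens) as the target (on this read-out lower numbers stand for stronger inhibition and higher numbers for weaker inhibition), compound 1 gives 3400 nM and compound 2 gives 2700 nM. Compound 1 has the higher of the two numbers shown, but the two values lie within the scatter of each other, so nothing about order or change can be read from them. Among the measured compounds shown here, no step between measured compounds is available to guide the next move.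

Compound 3 `CC(O)(C(=O)Nc1ccc(S(=O)(=O)c2cncs2)cc1)C(F)(F)F` has not yet been measured. It differs from compound 1 by 1,3-thiazol-5-yl in place of 3-fluorophenyl on a sulfonyl sulfur. For the measured compounds named here, with only two measured compounds, both in the same range, and no measured step, nothing beyond the scatter is expected from this change. The expected step is a 1.1-fold lower number from compound 1 to compound 3 (0.05 log units; within the scatter), no more than the usual scatter in either direction. Compound 3 is expected to give 3000 nM in this assay, with a range from 1000 nM to 9000 nM.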

Compound 3, half-maximal inhibitory concentration: 7700 nM
Estimate against measurement, compound 3: 2.6-fold (0.41 log units) below; the measured number falls inside the stated range.
By their numbers in this assay, from the lowest: compounds 2 and 1 (each within the scatter of the next); then compound 3.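

Among the compounds shown here, on the sulfonyl sulfur, 1,3-thiazol-5-yl in place of 3-fluorophenyl gives a 2.3-fold higher number from compound 1 to compound 3 (0.36 log units; beyond the scatter) in this assay and is the first step to lie beyond the scatter, though it is modest. This position therefore responds to the group it carries, and this change moves the read-out towards weaker inhibition. No measurement at hand accounts for the step.

Open, as far as these compounds go, is whether the step follows from losing the fluorine or from replacing the six-membered carbon ring with a five-membered ring holding hetero atoms. An unsubstituted phenyl and a pyridyl ring on the same sulfonyl sulfur would separate these two readings, and a thiophene ring would show whether the ring nitrogen of the thiazole matters.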